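Cyclopropyl for Methyl on a Trifluoromethyl Core

The source may hold more compounds than are shown below. What is called first, only, known or untested is meant among the compounds shown, and "the series" means these compounds.

Compound 1 `Cc1cc(Nc2nc(NCc3ccc(F)cc3F)nc3cc(Cl)ccc23)n[nH]1` is the anchor of this small set. In an assay for inhibition of high affinity nerve growth factor receptor (Homo sapiens), read by HTRF, with a stated time of 30 min, in the presence of a further agent that is not named here (on this read-out higher numbers stand for weaker inhibition and lower numbers for stronger inhibition), compound 1 gives 15 nM. Two single changes have been made from it. Compound 2 `Fc1ccc(CNc2nc(Nc3cc(C4CC4)[nH]n3)c3ccc(Cl)cc3n2)c(F)c1` differs from compound 1 by cyclopropyl in place of methyl on an aromatic carbon; in this assay compound 2 gives 290 nM, a step of a 19-fold higher number from compound 1 to compound 2 (1.29 log units; beyond the scatter). Compound 3 `Cc1cc(Nc2nc(NCc3ccc(F)cc3F)nc3cc(C(F)(F)F)ccc23)n[nH]1` differs from compound 1 by trifluoromethyl in place of chloro on an aromatic carbon; in this assay compound 3 gives 57 nM, a step of a 3.8-fold higher number from compound 1 to compound 3 (0.58 log units; beyond the scatter).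

Compound 4 `Fc1ccc(CNc2nc(Nc3cc(C4CC4)[nH]n3)c3ccc(C(F)(F)F)cc3n2)c(F)c1` has not yet been measured. It differs from compound 3 by cyclopropyl in place of methyl on an aromatic carbon. For the measured compounds named here, this is the same change as the one from compound 1 to compound 2, at a place described in exactly the same words, so the change is the same; the two cores differ only as already told, trifluoromethyl in place of chloro on an aromatic carbon. Going by the values given here, the one measured example of this change was large, so a step of similar size is expected here: the estimated step is a 16-fold higher number from compound 3 to compound 4 (1.20 log units; beyond the scatter), resting on the measured 19-fold higher number from compound 1 to compound 2 (1.29 log units; beyond the scatter). In this assay compound 4 is therefore expected to give about 900 nM, most likely between 300 nM and 3000 nM.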

Compound 4, half-maximal inhibitory concentration: 17 nM
Beside the measured number, compound 4's estimate is 53-fold (1.72 log units) above it, outside the stated range (below it).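

In this assay, cyclopropyl in place of methyl does not carry over from one core to the other, and on the trifluoromethyl core the step, a 3.4-fold lower number from compound 3 to compound 4 (0.53 log units; beyond the scatter), runs the opposite way to the one on the chloro core: the same change on two cores in this assay, a 19-fold higher number (1.29 log units; beyond the scatter) from compound 1 to compound 2 and a 3.4-fold lower number (0.53 log units; beyond the scatter) from compound 3 to compound 4, 65-fold (1.81 log units) apart, beyond the scatter of two such steps

Trifluoromethyl in place of chloro is no fixed step either, with a 17-fold lower number from compound 2 to compound 4 (1.23 log units; beyond the scatter) standing against the earlier step for that same swap: the same change on two cores in this assay, a 3.8-fold higher number (0.58 log units; beyond the scatter) from compound 1 to compound 3 and a 17-fold lower number (1.23 log units; beyond the scatter) from compound 2 to compound 4, 65-fold (1.81 log units) apart, beyond the scatter of two such steps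

So the effect of each change here depends on which group sits at the other place, which means that a step measured on one core is a poor guide to the next; these four compounds do not show why this happens, nor how either change would behave on any further core.

From the compounds shown here alone, it remains open whether an ethyl, an isopropyl or a cyclobutyl at the place held by methyl and cyclopropyl would follow the same reversal. Going by these compounds, it is equally open whether a nitrile or a methoxy in place of chloro would behave like chloro or like trifluoromethyl.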